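Swapping an Allyl Group for Hydrogen: Expected Cytotoxicity

The source may hold more compounds than are shown below. What is called first, only, known or untested is meant among the compounds shown, and "the series" means these compounds.

Compound 1 `COc1ccccc1/C=c1/[nH]c(=O)/c(=C\c2cccc(Cl)c2Cl)[nH]c1=O`: "not active" (no number reported)
Compound 2 `C=CCn1c(=O)/c(=C\c2ccccc2OC)[nH]c(=O)/c1=C\c1ccccc1OC`: 22400 nM

Of the compounds shown here, two have been tested in a functional assay on A549 cells (Homo sapiens) for cytotoxicity, read by CCK-8 assay, with a stated time of 72 h; on this read-out higher numbers stand for weaker inhibition and lower numbers for stronger inhibition. Compound 1 was reported as "not active" (no number reported), with no number given. Within the data shown here, compound 2 gives 22400 nM in this assay, the only numerical value so far, so compound 2 stands alone as the point of reference. Compound 3 `COc1ccccc1/C=c1/[nH]c(=O)/c(=C\c2ccccc2OC)[nH]c1=O` has not yet been measured. It differs from compound 2 in one place: hydrogen in place of allyl on an aromatic nitrogen. Among the measured compounds shown here, no step between two measured compounds exists to calibrate this change. Compound 1, which carries hydrogen on both ring nitrogens, gave "not active" (no number reported), and on that basis the step of a 2.7-fold higher number from compound 2 to compound 3 (0.43 log units; beyond the scatter) is expected to weaken inhibition in this assay. Compound 3 is therefore expected to give about 60000 nM in this assay, within a range from 15000 nM to 250000 nM, with a real chance that only a limit is reported.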

Compound 3, half-maximal inhibitory concentration: "not active" (no number reported)
For compound 3 the study gives words and no number; the estimate stays without a comparison.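

In this assay, among these compounds, compound 3 is reported as "not active" (no number reported) and only compound 2 has a number, so no step between compound 2 and compound 3 can be read. No measurement shown offers an explanation for this result. The compounds shown leave open how much swapping allyl for hydrogen changes inhibition.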